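The source may report more compounds than this note shows. Statements on the series, on what has been measured and on what is new or still open speak of the compounds shown alone.

Compound 1 `Cc1cn(C2OC(CO)C(C#N)C2O)c(=O)[nH]c1=O`: > 200 ug/mL
Compound 2 `N#C[C@@H]1[C@@H](O)[C@H](n2ccc(=O)[nH]c2=O)O[C@@H]1CO`: 400 ug/mL

In an ADME assay on Vero cells (Chlorocebus sabaeus) for cytotoxicity (on this read-out lower numbers stand for higher toxicity in this test and higher numbers for lower toxicity in this test), compound 1 gives > 200 ug/mL, which is a limit of the test rather than a number. Compound 2 holds the only number shown: in this assay compound 2 gives 400 ug/mL. The value of compound 1 is a limit (the limit of > 200 ug/mL in this assay, at which 1 of the 2 values shown sits). Compound 3 `N#C[C@H]1[C@@H](O)[C@H](n2ccc(=O)[nH]c2=O)O[C@@H]1CO` is not yet measured. It differs from compound 2 only in configuration: the two compounds have the same atoms and bonds and differ only in configuration as drawn: 1 of 4 stereo elements differ; a stereocentre at a saturated ring carbon is drawn R in compound 2 and S in compound 3. For the measured compounds named here, no measured step between two compounds is available, so in this assay the step of no change at the digits printed from compound 2 to compound 3 (within the scatter) is expected to stay within the scatter. Compound 3 is therefore estimated at 400 ug/mL, within 200 ug/mL to 800 ug/mL.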

Compound 3, minimum cytotoxic concentration: > 200 ug/mL
Compound 3: no number, only a limit (the forecaster's own chance of this, stated with the estimate: 40%); the middle value is on the limit's open side.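

Compound 3 gives only a limit in this assay, so no step can be read between compound 2 and compound 3. From the compounds shown here alone, whether drawing the saturated ring carbon stereocentre S rather than R changes the minimum cytotoxic concentration stays open.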